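The source may hold more compounds than are shown below. What is called first, only, known or untested is meant among the compounds shown, and "the series" means these compounds.

Compounds measured in a functional assay on HT-29 cells (Homo sapiens) for inhibition, read by MTT assay, with a stated time of 72 h; a higher number here means a weaker inhibitor, a lower number a stronger inhibitor:
- compound 1 `C=C(Br)C(=O)Nc1cccc(/C=C/C(=O)Nc2ccccc2)c1`: 16600 nM
- compound 2 `C=C(Br)C(=O)Nc1cccc(/C=C/C(=O)Nc2ccc(F)cc2)c1`: 36600 nM
- compound 3 `C=C(Br)C(=O)Nc1cccc(/C=C/C(=O)Nc2ccc(F)c(F)c2)c1`: 8700 nM

Two steps fix where compound 3 stands: a 1.9-fold lower number from compound 1 to compound 3 (0.28 log units; within the scatter), and a 4.2-fold lower number from compound 2 to compound 3 (0.62 log units; beyond the scatter). The next compound, compound 4 `C=C(Br)C(=O)Nc1cccc(/C=C/C(=O)Nc2ccc(Cl)cc2)c1`, has 4-chlorophenyl in place of 3,4-difluorophenyl on an amide-type nitrogen. For the measured compounds named here, no chloro compound has been measured yet, so only the fluoro steps bear on this change, and they do not agree in direction. Alongside the modest rise to compound 3 from compound 2 stands another modest step: a 2.2-fold higher number from compound 1 to compound 2 (0.34 log units; beyond the scatter). Compound 4 resembles compound 2, at 36600 nM, in carrying one halogen on that ring rather than two. A small move toward a higher number is therefore expected, probably not one clearly beyond the scatter. The estimated step is a 1.6-fold higher number from compound 3 to compound 4 (0.21 log units; within the scatter). Compound 4 is expected at 14000 nM, with an estimated range of 5500 nM to 36000 nM.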

Compound 4, half-maximal inhibitory concentration: 7900 nM
Beside the measured number, compound 4's estimate is 1.8-fold (0.25 log units) above it; measured number inside the range.
By their numbers in this assay, from the lowest: compounds 4, 3 and 1 (each within the scatter of the next, the first and the last beyond it); then compound 2.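

With a 1.1-fold lower number from compound 3 to compound 4 (0.04 log units; within the scatter) in this assay a lone 4-chlorophenyl on the amide-type nitrogen cannot be told apart from 3,4-difluorophenyl, so a second halogen on this ring is not needed to reach this level. With a 4.6-fold lower number from compound 2 to compound 4 (0.67 log units; beyond the scatter) it becomes clear that the kind of single halogen counts here, not only the presence of one. Against the plain phenyl, a 2.1-fold lower number from compound 1 to compound 4 (0.32 log units; beyond the scatter) runs opposite in direction to a 2.2-fold higher number from compound 1 to compound 2 (0.34 log units; beyond the scatter) and so chloro and fluoro in place of hydrogen part ways at this position.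

On these data alone, whether a bromo, methyl or methoxy group on this ring would fall with compound 4 or with compound 2 stays open. Nothing available here explains why chloro and fluoro differ.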